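This account rests on a few compounds, and the source may have more. Where it says the series, first, only, none or still open, it means among the compounds named here.

Within the data shown here, compound 1 `C=C(Br)C(=O)Nc1cccc(-c2cn3nc(-c4ccc(F)cc4)sc3n2)c1` is the only member of this set with a numerical potency. Among the measured compounds shown here, in a functional assay on CCRF-CEM cells (Homo sapiens) for inhibition, read by cell counting, with a stated time of 3 days (a lower number here means a stronger inhibitor, a higher number a weaker inhibitor), compound 1 gives 830 nM, and that is the single number reported. Compound 2 `COc1ccc(Cc2nn3cc(-c4cccc(N)c4)nc3s2)cc1` is known only as a limit of the assay. In this assay compound 2 is recorded as >= 250000 nM, a limit rather than a number. Compound 2 and compound 1 differ in several places at once, so nothing beyond the fact that one has a number and the other a limit can be drawn from them (the limit of >= 250000 nM in this assay, at which 1 of the 2 values shown sits). Compound 3 `C=C(Br)C(=O)Nc1cccc(-c2cn3nc(-c4cccc(OC)c4)sc3n2)c1` has not yet been measured. It differs from compound 1 by 3-methoxyphenyl in place of 4-fluorophenyl on an aromatic carbon. No change between measured compounds sets a scale for this kind of swap. Exchanging one aromatic ring for another of similar size at this position most often produces a shift at or only slightly beyond the scatter, and a small loss seems somewhat more likely than a gain. Compound 3 is therefore expected to give 1300 nM in this assay, with a range from 400 nM to 4500 nM. This expectation amounts to an estimated step of a 1.6-fold higher number from compound 1 to compound 3 (0.19 log units; within the scatter).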

Compound 3, half-maximal inhibitory concentration: 1200 nM
The estimate for compound 3 lay 1.1-fold (0.03 log units) above the measured number; the range from low to high includes it.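

Among these compounds, replacing 4-fluorophenyl with 3-methoxyphenyl on this aromatic carbon gives the first step in the set that can be read, and in this assay it is a 1.4-fold higher number from compound 1 to compound 3 (0.16 log units; within the scatter) for this pair. The shared core and the bromo-substituted acrylamide stay the same, and the entering group brings a hydrogen-bond acceptor that the leaving group does not have, yet compound 1 and compound 3 cannot be told apart here, so this position accepts both of these substituted phenyl rings without a change that exceeds the scatter. Nothing measured among the compounds shown speaks to why these two compounds read alike.

The compounds shown leave open how this position responds to anything other than a substituted phenyl ring, such as an amine, a carboxylic acid or a longer alkyl chain, since a single pair sets no trend for the position. As far as these compounds go, compound 2 remains a limit of the assay at >= 250000 nM and differs from compound 1 in several places, so which of those differences matters also stays open.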